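Cytotoxicity notes on a cyclohexylamino analogue of compound 3

The source may hold more compounds than are shown below. What is called first, only, known or untested is meant among the compounds shown, and "the series" means these compounds.

Measured so far:
Compound 1 `O=c1n(Cc2nc3cc(Cl)ccn3c2CCCCO)c2cnccc2n1C1CC1`: in an ADME assay on HEp-2 cells (Homo sapiens) for cytotoxicity, read by CCK-8 assay, with a stated time of 6 days (a lower number here means that less compound is tolerated, a higher number that more compound is tolerated), compound 1 gives > 100000 nM, which is a limit of the assay and not a number.
Compound 2 `N#Cc1c(Cn2c(=O)n(C3CC3)c3ccncc32)nc2cc(Cl)ccn12`: in this assay compound 2 gives 22500 nM.
Compound 3 `NC(=O)CCc1c(Cn2c(=O)n(C3CC3)c3ccncc32)nc2cc(Cl)ccn12`: in this assay compound 3 gives > 100000 nM, again a limit of the assay.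

Compound 3 thus sits at the limit of > 100000 nM in this assay, at which 2 of the 3 values shown sit, where compound 1 also sits; only compound 2 returns a number. The steps that touch compound 3 are an at least 4.4-fold higher number from compound 2 to compound 3 (0.64 log units; beyond the scatter) and a step that the two limits leave unreadable from compound 1 to compound 3. For the measured compounds named here, the one change that produced a readable number was an at least 4.4-fold lower number from compound 1 to compound 2 (0.64 log units; beyond the scatter), where a small cyano entered; the 4-hydroxybutyl of compound 1 and the 2-carbamoylethyl of compound 3 both leave the value at the limit, so compound 2 is the only exception to an otherwise flat picture.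

The next compound, compound 4 `O=c1n(Cc2nc3cc(Cl)ccn3c2NC2CCCCC2)c2cnccc2n1C1CC1`, differs from compound 3 by cyclohexylamino in place of 2-carbamoylethyl on an aromatic carbon. A bulky substituent at this position has so far gone with a limit rather than a number, and compound 4 is expected to behave the same way, giving a step of an at least 1.4-fold lower number from compound 3 to compound 4 (0.15 log units; that floor lies within the scatter). The estimated value for compound 4 is 70000 nM, with a range from 15000 nM to 100000 nM.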

Compound 4, half-maximal cytotoxic concentration: > 100000 nM
Compound 4 was reported as a limit (the forecaster's own chance of this, stated with the estimate: 55%); middle value at least 1.4-fold (0.15 log units) from the limit.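

With cyclohexylamino, a non-aromatic ring joined through nitrogen to this aromatic carbon, compound 4 gives > 100000 nM in this assay, a limit of the assay and not a number, so the limit is no longer tied to the open chains that sat here before. The change from the nitrile gives an at least 4.4-fold higher number from compound 2 to compound 4 (0.64 log units; beyond the scatter), while the steps joining compound 4 to compound 1 and compound 3 cannot be read, as both ends of each are limits. Compound 2 remains the one compound against this pattern at the position: the limit of > 100000 nM in this assay, at which 3 of the 4 values shown sit.

Compounds 1, 3 and 4 cannot be ordered among themselves. Going by these compounds, whether a readable number is particular to the nitrile of compound 2, or would also appear with a methyl, an unsubstituted amine or a carboxylic acid on this carbon, stays open.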